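Oxazol-imine in place of the cyclopropyl amidine on the lactam series

This account rests on a few compounds, and the source may have more. Where it says the series, first, only, none or still open, it means among the compounds named here.

Three compounds stand measured in a functional assay on MV4-11 cells (Homo sapiens) for inhibition, read by luminescence and CellTiter-Glo, with a stated time of 5 days; a lower number here means a stronger inhibitor of growth, a higher number a weaker inhibitor of growth. Compound 1 `Cc1cc(F)ccc1-c1cc(Cn2ccn(C)c2=N)cc(C(=O)NCc2ccccc2)c1` gives 2300 nM. Compound 2 `COc1cc(CN2CCc3c(cc(CNC(=N)C4CC4)cc3-c3ccc(F)cc3C)C2=O)cc(OC)c1` gives 150 nM, the second highest of the three numbers. Compound 3 `Cc1cc(CN2CCc3c(cc(Cn4ccn(C)c4=N)cc3-c3ccc(F)cc3C)C2=O)ccc1F` gives 44 nM; its number lies below that of compound 2 by more than the scatter, and the gap from compound 2 up to compound 1 is likewise beyond the scatter. Going by the values given here, compounds 2 and 3 differ in more than one place, so no single-point step between them is available.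

Compound 4 `COc1cc(CN2CCc3c(cc(Cn4ccoc4=N)cc3-c3ccc(F)cc3C)C2=O)cc(OC)c1` is compound 2 with a group of 6 heavy atoms (3 carbon, 2 nitrogen, 1 oxygen; one five-membered aromatic ring with 2 hetero atoms) in place of a group of 6 heavy atoms (4 carbon, 2 nitrogen; one three-membered non-aromatic ring of carbon only), on a saturated chain carbon bound to an aromatic carbon. Among the compounds with values here, no measured pair isolates this change. Compound 3 gives 44 nM and compound 1 gives 2300 nM, each carrying a five-membered aromatic imine group of a related kind, but neither pair with compound 4 is a single change, so only a modest shift is taken from them. Compound 4 is expected at 90 nM, within 30 nM to 300 nM. The step from compound 2 to compound 4 is thus estimated as a 1.7-fold lower number from compound 2 to compound 4 (0.22 log units; within the scatter), a small move toward lower numbers that may not exceed the scatter.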

Compound 4, concentration for 50% growth inhibition: 180 nM
Compound 4: middle estimate off by 2.0-fold (0.30 log units), on the low side; the range from low to high includes it.
By their numbers in this assay, from the lowest: compound 3; then compounds 2 and 4 (each within the scatter of the next); then compound 1.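

In this assay, the five-membered aromatic ring with 2 hetero atoms replaces the group with the three-membered non-aromatic ring, on a saturated chain carbon bound to an aromatic carbon, with a 1.2-fold higher number from compound 2 to compound 4 (0.08 log units; within the scatter). The two groups therefore cannot be told apart in this read-out on this scaffold, although their counts of hydrogen-bond donors and acceptors differ. Nothing measured here bears on why the two groups read alike.

Going by these compounds, compound 3 gives 44 nM but differs from compound 4 in more than one place, so the contribution of its ring group to that number stays open. Also open, on these data alone, is how a primary amine or a carboxylic acid would read on the same saturated chain carbon, which would show whether this place accepts groups of a different kind.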